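This account rests on a few compounds, and the source may have more. Where it says the series, first, only, none or still open, it means among the compounds named here.

Of the compounds shown here, two have been measured in an ADME assay on 184B5 cells (Homo sapiens) for cytotoxicity, read by MTT assay, with a stated time of 72 h; a higher number here means a weaker inhibitor of growth, a lower number a stronger inhibitor of growth. Compound 1 `CC(C)COC(=O)Nc1ccc([Se][Se]c2ccc(NC(=O)OCC(C)C)cc2)cc1`, a symmetric structure in which two carbamate-bearing phenyl rings are joined through a pair of selenium atoms, gives 10500 nM in this assay. Compound 2 `N#C[Se]c1ccc(NC(=O)Oc2ccc(F)cc2)cc1`, which carries a selenocyanate group on one ring and a fluorinated phenyl carbamate on the other, gives 29500 nM. Compound 2 thus stands as the higher of the two numbers, and the gap between compound 1 and compound 2 lies beyond the usual scatter of repeated measurements.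

Compound 3 `N#C[Se]c1ccc(NC(=O)Oc2ccccc2)cc1` is the next compound to be measured. It differs from compound 2 at a single place: hydrogen in place of fluoro on an aromatic carbon. For the measured compounds named here, since no measured pair here shows the effect of such a change, the expectation is a small step from compound 2 to compound 3 in this assay, a 1.1-fold lower number from compound 2 to compound 3 (0.02 log units; within the scatter), most likely none beyond the scatter. Compound 3 is therefore estimated at 28000 nM, with a plausible range from 12000 nM to 65000 nM.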

Compound 3, concentration for total growth inhibition: 22700 nM
Compound 3: middle estimate off by 1.2-fold (0.09 log units), on the high side; the range from low to high includes it.
By their numbers in this assay, from the lowest: compound 1; then compounds 3 and 2 (each within the scatter of the next).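

In this assay, putting hydrogen in place of the fluoro on this aromatic carbon, para to a large group, gives a 1.3-fold lower number from compound 2 to compound 3 (0.11 log units; within the scatter). For the compounds shown here, this is the first pair that isolates a single change, and it shows that, at this position, the assay does not separate fluoro from hydrogen. Compounds with and without this one fluorine can therefore be read as equal here, though only for this pair. No measurement at hand speaks to the reason for this result.

The pair does not show how a larger group at the same place, such as a methoxy group, a trifluoromethyl group or an amine, would read. Also open, from the compounds shown here alone, is whether the same swap on another aromatic carbon of this ring would stay within the scatter.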